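Swapping a chlorophenyl for a thiazole on the alkyne arm

This account rests on a few compounds, and the source may have more. Where it says the series, first, only, none or still open, it means among the compounds named here.

Of the compounds shown here, three sharing one core have been measured in an assay on CHO cells for displacement of a labelled ligand from adenosine receptor A1 (Homo sapiens), read by scintillation counting, with a stated time of 60 min, tested at 10 uM; a higher number here means more inhibition at the concentration tested (going by the name of the read-out), a lower number less inhibition. Compound 1 `CNC(=O)[C@@]12C[C@@H]1[C@@H](n1cnc3c(NC)nc(C#Cc4ccc(Cl)cc4)nc31)[C@H](O)[C@@H]2O` gives 13%. Compound 2 `CNC(=O)[C@@]12C[C@@H]1[C@@H](n1cnc3c(NC)nc(C#Cc4ccc(OC)cc4)nc31)[C@H](O)[C@@H]2O` gives 10%, and compound 3 `CCc1ccc(C#Cc2nc(NC)c3ncn([C@H]4[C@H](O)[C@H](O)[C@]5(C(=O)NC)C[C@H]45)c3n2)o1` gives 18%. Compound 1 sits in the middle of these three numbers, all of which lie within the scatter of one another: a number 3 percentage points lower from compound 1 to compound 2 (within the scatter), and a number 5 percentage points higher from compound 1 to compound 3 (within the scatter).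

Compound 4 `CNC(=O)[C@@]12C[C@@H]1[C@@H](n1cnc3c(NC)nc(C#Cc4nccs4)nc31)[C@H](O)[C@@H]2O` differs from compound 1 in one place: 1,3-thiazol-2-yl in place of 4-chlorophenyl on a triple-bonded carbon. Within the data shown here, the closest precedent is the change from compound 1 to compound 3, where another five-membered aromatic ring with hetero atoms replaced the 4-chlorophenyl group; that step, and the step from compound 1 to compound 2, both stayed within the scatter. No shift beyond the scatter in this assay is therefore expected: compound 4 is estimated to give 14% (range 3% to 28%), meaning an expected a number 1 percentage points higher from compound 1 to compound 4 (within the scatter).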

Compound 4, a percentage reported as inhibition, at one concentration (the size of the read-out at that concentration, not a potency): 31%
Compound 4: the middle estimate sits 17 percentage points below what was measured, and the stated range ends below it.
By their numbers in this assay, from the lowest: compounds 2, 1 and 3 (each within the scatter of the next); then compound 4.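

In this assay, among these compounds, this is the first change on the triple-bonded carbon to go beyond the scatter, with 1,3-thiazol-2-yl compared against 4-chlorophenyl (a number 18 percentage points higher from compound 1 to compound 4 (beyond the scatter)), 5-ethylfuran-2-yl (a number 13 percentage points higher from compound 3 to compound 4 (beyond the scatter)) and 4-methoxyphenyl (a number 21 percentage points higher from compound 2 to compound 4 (beyond the scatter)). The position therefore does respond to the ring placed there, although the three earlier groups could not be told apart. Nothing available explains the rise.

Which atoms of the 1,3-thiazol-2-yl ring matter stays open. So does whether a pyridine ring, an unsubstituted furan or an amine on the same carbon would give a similar number.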